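A few compounds are considered here, and "the series" means these few. Any claim that something is new, unique, unknown or untested is made for them only; others in the source may bear on it.

Measured in a functional assay on the whole organism (blood, strain Wistar-Okamoto) with Rattus norvegicus as the target, with a stated time of 5 days; a lower number here means that less compound is needed, a higher number that more compound is needed for the effect:
compound 1, `CC(C)CC(C)(C)/N=C(\NC#N)Nc1cccnc1`; compound 1 gives 2.5 mg/kg
compound 2, `CC(C)(C)CC(C)(C)/N=C(\NC#N)Nc1cccnc1`; compound 2 gives 50 mg/kg
compound 3, `CC(C)CC(C)(C)/N=C(\NC#N)Nc1ccncc1`; compound 3 gives 20 mg/kg

Two single changes are measured in this set. From compound 1 to compound 2 the change is methyl in place of hydrogen on a saturated chain carbon bound to three saturated chain carbons, and it reads a 20-fold higher number from compound 1 to compound 2 (1.30 log units; beyond the scatter). The two cores of compound 1 and compound 3 differ by pyridin-4-yl in place of pyridin-3-yl on an amine nitrogen, and that step reads an 8.0-fold higher number from compound 1 to compound 3 (0.90 log units; beyond the scatter). For the measured compounds named here, compound 3 thus stands second highest of the three numbers, with compound 2 the nearest neighbour and compound 1 the furthest; no step is counted between compound 2 and compound 3, and their two values alone show compound 2 the higher.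

Compound 4, `CC(C)(C)CC(C)(C)/N=C(\NC#N)Nc1ccncc1`, is not yet measured. It differs from compound 3 by methyl in place of hydrogen on a saturated chain carbon bound to three saturated chain carbons, which is the same change made from compound 1 to compound 2, at a place described in the same words. Going by the values given here, the only measured instance of this change is a 20-fold higher number from compound 1 to compound 2 (1.30 log units; beyond the scatter), a large step and the only basis available; whether the change behaves alike on the core of compound 3 is not known from these three compounds. On that basis the step from compound 3 to compound 4 is expected to be a 10-fold higher number from compound 3 to compound 4 (1.00 log units; beyond the scatter), close to the earlier one. Compound 4 is therefore estimated at 200 mg/kg, expected to lie between 50 mg/kg and 600 mg/kg. A number this high may exceed the doses tested, so a limit rather than a number is a real possibility for compound 4.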

Compound 4, minimum effective dose: 50 mg/kg
Compound 4: the middle estimate sits 4.0-fold (0.60 log units) above what was measured; the range from low to high includes it.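

In this assay the methyl in place of hydrogen on a saturated chain carbon bound to three saturated chain carbons keeps its direction on the second core but gives only a 2.5-fold higher number from compound 3 to compound 4 (0.40 log units; beyond the scatter), so the size of the step does not carry from one core to the other: the same change on two cores in this assay, a 20-fold higher number (1.30 log units; beyond the scatter) from compound 1 to compound 2 and a 2.5-fold higher number (0.40 log units; beyond the scatter) from compound 3 to compound 4, 8.0-fold (0.90 log units) apart, beyond the scatter of two such steps. The ring change depends in turn on the chain, reading no change at the digits printed from compound 2 to compound 4 (within the scatter), and so differs from its earlier size: the same change on two cores in this assay, an 8.0-fold higher number (0.90 log units; beyond the scatter) from compound 1 to compound 3 and no change at the digits printed (within the scatter) from compound 2 to compound 4, 8.0-fold (0.90 log units) apart, beyond the scatter of two such steps. For the compounds shown here, these four compounds show that the two changes do not add up independently, but they do not show why, and with only two instances of each change they give no rule for any further core.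

As far as these compounds go, how the methyl step would read with pyridin-2-yl or phenyl on the amine nitrogen remains open. Also open, from the compounds shown here alone, is whether ethyl or a longer chain in place of the methyl, on the same carbon, would separate the two cores or leave them as close as compound 2 and compound 4.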